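A tert-Butyl Group in Place of Ethyl

The source may hold more compounds than are shown below. What is called first, only, known or untested is meant among the compounds shown, and "the series" means these compounds.

Compounds measured in a functional assay on KB-V1 cells (Homo sapiens) for cytotoxicity, read by MTT assay, with a stated time of 72 h; a lower number here means a stronger inhibitor, a higher number a weaker inhibitor
- compound 1 `O=C1Nc2ccccc2/C1=N/NC(=S)Nc1ccc(Cl)cc1` (4990 nM)
- compound 2 `O=C1Nc2ccccc2/C1=N/NC(=S)Nc1ccc(C(F)(F)F)cc1` (2100 nM)
- compound 3 `CCc1ccc(NC(=S)N/N=C2\C(=O)Nc3ccccc32)cc1` (1340 nM)

Compound 3 (1340 nM) sits at the low end of these numbers, together with compound 2 (2100 nM). Compound 1 (4990 nM) stands apart from it (a 3.7-fold lower number from compound 1 to compound 3 (0.57 log units; beyond the scatter)), while the remaining gap is small (a 1.6-fold lower number from compound 2 to compound 3 (0.20 log units; within the scatter)). The next compound, compound 4 `CC(C)(C)c1ccc(NC(=S)N/N=C2\C(=O)Nc3ccccc32)cc1`, carries tert-butyl in place of ethyl on an aromatic carbon, para to a large group (tert-butyl in place of ethyl on an aromatic carbon). Exchanges at this place have so far produced only modest steps (a 2.4-fold lower number from compound 1 to compound 2 (0.38 log units; beyond the scatter)), and the two steps into compound 3 are no larger than modest. Among the measured compounds shown here, none of the measured steps replaces one alkyl group with a larger one, so the direction remains open. The expected step in this assay is therefore none beyond the scatter (a 1.1-fold lower number from compound 3 to compound 4 (0.05 log units; within the scatter)). Compound 4 is estimated at 1200 nM, with an expected range from 480 nM to 3000 nM.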

Compound 4, half-maximal inhibitory concentration: 710 nM
Compound 4: the middle estimate sits 1.7-fold (0.23 log units) above what was measured, and the stated range covers the measured number.
By their numbers in this assay, from the lowest: compounds 4, 3 and 2 (each within the scatter of the next, the first and the last beyond it); then compound 1.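

In this assay, among the compounds shown here, the first exchange of one alkyl group for a larger one on this aromatic carbon stays within the scatter (a 1.9-fold lower number from compound 3 to compound 4 (0.28 log units; within the scatter)), so ethyl and tert-butyl are not separated here. For the compounds shown here, measured against the non-alkyl groups, however, tert-butyl shows a step beyond the scatter from trifluoromethyl (a 3.0-fold lower number from compound 2 to compound 4 (0.47 log units; beyond the scatter)), which ethyl did not, and its step from chloro (a 7.0-fold lower number from compound 1 to compound 4 (0.85 log units; beyond the scatter)) is the largest seen at this place so far, though still modest. The data offer no explanation for any of these steps.

The compounds shown leave open how an amine, a carboxylic acid or a methoxy group would read at this place. They also leave open whether a longer chain, such as n-hexyl, would keep the number in the range of the two alkyl compounds.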